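Methylating the free hydroxy group of compound 1

The source may report more compounds than this note shows. Statements on the series, on what has been measured and on what is new or still open speak of the compounds shown alone.

Measured in a functional assay on CCRF-CEM cells (Homo sapiens) for cytotoxicity, read by sulforhodamine B assay, with a stated time of 48 h; a higher number here means a weaker inhibitor of growth, a lower number a stronger inhibitor of growth:
- compound 1 `COc1cc(C(=O)c2ccc(OC)c(O)c2OC)cc(OC)c1O`: 896 nM
- compound 2 `COc1cc(C(=O)c2ccc3c(c2)oc(=O)n3S(C)(=O)=O)cc(OC)c1OC`: 3350 nM

Compound 1, at 896 nM, holds the lower of the two numbers and is therefore the stronger growth inhibitor of the pair. Compound 2, at 3350 nM, lies beyond the usual scatter from it. The two compounds differ in more than one place, so their gap says nothing about any single structural change.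

The next compound is compound 3 `COc1ccc(C(=O)c2cc(OC)c(OC)c(OC)c2)c(OC)c1O`. Relative to compound 1, one hydroxy becomes methoxy, with methyl in place of hydrogen on an oxygen on an aromatic ring. For the measured compounds named here, no pair of measured compounds differs in one place, so no measured step bears on this change, and the expectation here is a judgement with little support from the data. In this assay, the expected change is a 3.0-fold lower number from compound 1 to compound 3 (0.48 log units; beyond the scatter), a moderate move towards stronger growth inhibition, although a result within the scatter would remain plausible. For compound 3 the estimated value is 300 nM, with an expected range from 70 nM to 1200 nM.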

Compound 3, concentration for 50% growth inhibition: 28.8 nM
The estimate for compound 3 lay 10-fold (1.02 log units) above the measured number; measured number outside the range, below it.
By their numbers in this assay, from the lowest: compound 3; then compound 1; then compound 2.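

In this assay, for the compounds shown here, the change from hydroxy to methoxy gives a 31-fold lower number from compound 1 to compound 3 (1.49 log units; beyond the scatter), a large move beyond the scatter and the first step that isolates a single structural change. The free hydroxy on this aromatic ring is therefore not required for growth inhibition in these cells: methyl in place of its hydrogen gives a much stronger inhibitor, with compound 3 at 28.8 nM. No available data bear on why this one added methyl has so large an effect.

From the compounds shown here alone, this is a single step, so it remains open whether the trend continues with an ethyl or longer chain on the same oxygen, or whether the gain survives replacing the oxygen substituent with an amine or a fluorine atom. Going by these compounds, it is also open whether the hydroxy group still present in compound 3 would respond to methylation in the same way, since one step at one position says nothing about the other positions on the shared core.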